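Replacing a Phenol Ring with Furan on the Pyridinone Core

This account rests on a few compounds, and the source may have more. Where it says the series, first, only, none or still open, it means among the compounds named here.

Going by the values given here, compound 2 `COc1cc(-c2cc(-c3cc(C(C)C)c(O)cc3C)[nH]c(=O)c2C#N)ccc1O` gives 32% in a functional assay for inhibition, tested at 40 ug/mL (a higher number here means a stronger effect of the compound at the concentration tested, a lower number a weaker effect), the lower of the two numbers measured so far; its nearest neighbour is compound 1 `Cc1cc(O)c(C(C)C)cc1-c1cc(-c2cccs2)c(C#N)c(=O)[nH]1`, which gives 41%, a difference within the scatter. Among the compounds with values here, the only step measured between them, thiophen-2-yl exchanged for 4-hydroxy-3-methoxyphenyl, was a number 9 percentage points lower from compound 1 to compound 2 (within the scatter). Compound 3 `Cc1cc(O)c(C(C)C)cc1-c1cc(-c2ccco2)c(C#N)c(=O)[nH]1` differs from compound 2 in the same position: furan-2-yl in place of 4-hydroxy-3-methoxyphenyl on an aromatic carbon. Because compound 1, which carries thiophen-2-yl at that place, showed a number 9 percentage points lower from compound 1 to compound 2 (within the scatter), a return to a small five-membered aromatic group is expected to shift the read-out by no more than the scatter. The estimated step of a number 6 percentage points higher from compound 2 to compound 3 (within the scatter) therefore reflects little change beyond the noise. Compound 3 is expected to give about 38% in this assay, within a range from 22% to 54%.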

Compound 3, a percentage reported as inhibition, at one concentration (the size of the read-out at that concentration, not a potency): 42.5%
For compound 3 the middle estimate is 4.5 percentage points below the measured one; low and high end bracket the measured number.
By their numbers in this assay, from the lowest: compounds 2, 1 and 3 (each within the scatter of the next, the first and the last beyond it).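

In this assay, going by these compounds alone, furan-2-yl in place of 4-hydroxy-3-methoxyphenyl gave a number 10.5 percentage points higher from compound 2 to compound 3 (beyond the scatter), the only step at this position that clears the scatter, so the read-out does respond to the group placed here, if only slightly. Furan-2-yl in place of thiophen-2-yl gave a number 1.5 percentage points higher from compound 1 to compound 3 (within the scatter), so this assay does not tell these two five-membered aromatic rings apart. Nothing measured here speaks to the reason for either step.

The compounds shown leave open whether the step from compound 2 goes with the six-membered ring itself or with its hydroxy and methoxy groups, a question that an unsubstituted phenyl at this place would address. Also open, as far as these compounds go, is how a non-aromatic group here, such as an amine or a carboxylic acid, would compare with the two five-membered rings.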